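A Second Methoxy Step in a Cell Growth Series

The compounds below may be only part of what the source reports. "The series", "measured", "known", "first", "only" and "open" are said of these compounds alone.

In a functional assay on NCI-H322M cells (Homo sapiens) for cytotoxicity, read by sulforhodamine B assay, with a stated time of 48 h, tested at 0.1 uM (on this read-out higher numbers stand for a weaker effect at the one concentration tested and lower numbers for a stronger effect), the measured compounds are:
compound 1 `COc1ccc(-c2cc(/C=C/C(=O)c3ccc(N)cc3)[nH]n2)cc1` with 89%
compound 2 `COc1ccc(C(=O)/C=C/c2cc(-c3cc(OC)c(OC)c(OC)c3)n[nH]2)cc1OC` with 101%
compound 3 `COc1ccc(-c2cc(/C=C/C(=O)c3ccc(N)cc3)[nH]n2)cc1OC` with 102%

Compound 3 differs from compound 1 by methoxy in place of hydrogen on an aromatic carbon, and in this assay this gave a number 13 percentage points higher from compound 1 to compound 3 (beyond the scatter). How the core of compound 2 differs from the core of compound 1 is not broken down here; compound 2 and compound 3 differ by a number within the usual scatter, so nothing can be said of their order.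

Compound 4 `COc1cc(C(=O)/C=C/c2cc(-c3cc(OC)c(OC)c(OC)c3)n[nH]2)cc(OC)c1OC` differs from compound 2 by methoxy in place of hydrogen on an aromatic carbon. This is the same kind of change as from compound 1 to compound 3, but not the same: around the place in compound 4 the entering group is also meta to a methoxy group, which is not so in compound 3.

Compound 2 already gives a number close to the top of the read-out in this assay, so the expected step of a number 2 percentage points higher from compound 2 to compound 4 (within the scatter) is smaller than the earlier one and lies within the scatter. For compound 4 the estimated value in this assay is 103%, with an expected range from 92% to 114%.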

Compound 4, a percentage reported as activity, at one concentration (the size of the read-out at that concentration, not a potency): 97%
Estimate against measurement, compound 4: 6 percentage points above; the measured number falls inside the stated range.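

In this assay, methoxy in place of hydrogen on an aromatic carbon gave a number 4 percentage points lower from compound 2 to compound 4 (within the scatter), so no change can be read from this step on the core of compound 2. Set beside the earlier step, the same change did not carry over from one core to the other with the same size: the same change on two cores in this assay, a number 13 percentage points higher (beyond the scatter) from compound 1 to compound 3 and a number 4 percentage points lower (within the scatter) from compound 2 to compound 4, 17 percentage points apart, beyond the scatter of two such steps. This does not show what sets the two steps apart, since the pairs differ in their cores and also around the place of the change, and two pairs tested at one concentration give no rule for any other core.

The compounds shown leave open whether a different group at the same place, such as ethoxy or a carboxylic acid, would follow either step. They also leave open how the two steps would compare on a core whose starting number lies further from the top of the read-out.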